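Methoxyphenyl in Place of Difluorophenyl on a Nucleoside Core

The compounds below may be only part of what the source reports. "The series", "measured", "known", "first", "only" and "open" are said of these compounds alone.

Compound 1 `COc1ccc(-c2ncnc3c2ncn3[C@@H]2O[C@H](COC(C)=O)[C@@H](OC(C)=O)[C@H]2OC(C)=O)cc1`: 4300 nM
Compound 2 `OC[C@H]1OC(n2cnc3c(-c4ccc(F)c(F)c4)ncnc32)[C@H](O)[C@@H]1O`: 1400 nM
Compound 3 `CC(=O)OC[C@H]1O[C@@H](n2cnc3c(-c4ccc(Cl)cc4)ncnc32)[C@H](OC(C)=O)[C@@H]1OC(C)=O`: 4300 nM

Of the compounds shown here, three have been measured in a functional assay on CCRF-CEM cells (Homo sapiens) for inhibition; on this read-out lower numbers stand for stronger inhibition and higher numbers for weaker inhibition. Compound 2 holds the lowest of the three numbers, with 1400 nM; compound 1 and compound 3 each lie beyond the scatter above it. Going by the values given here, the one single-point step on record, no change at the digits printed from compound 1 to compound 3 (within the scatter), shows that swapping a methoxy for a chloro on the aryl ring of the acetylated series left the read-out unchanged.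

Compound 4 `COc1cccc(-c2ncnc3c2ncn3C2O[C@H](CO)[C@@H](O)[C@H]2O)c1` differs from compound 2 by 3-methoxyphenyl in place of 3,4-difluorophenyl on an aromatic carbon. Among the compounds with values here, no measured pair isolates this exact change: compound 2 differs from compound 1 and compound 3 in both the aryl substituent and the sugar protection, so only their values, not a clean step, can be read. Within the data shown here, the only aryl-only step, from compound 1 to compound 3, was flat, which argues for a small move at most. Compound 4 is therefore expected to land near compound 2, with a modest weakening allowed for: the estimated step is a 1.8-fold higher number from compound 2 to compound 4 (0.25 log units; within the scatter). The estimate for compound 4 in this assay is 2500 nM, within a range from 800 nM to 8000 nM.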

Compound 4, half-maximal inhibitory concentration: 4800 nM
The estimate for compound 4 lay 1.9-fold (0.28 log units) below the measured number, within the range that was stated.
By their numbers in this assay, from the lowest: compound 2; then compounds 1, 3 and 4 (each within the scatter of the next).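

In this assay, going by these compounds alone, the change from 3,4-difluorophenyl to 3-methoxyphenyl gives a 3.4-fold higher number from compound 2 to compound 4 (0.54 log units; beyond the scatter) and is the first aryl-only step on the unacetylated sugar, showing that this position can respond to the aryl group it carries. The earlier aryl-only step on the acetylated sugar, no change at the digits printed from compound 1 to compound 3 (within the scatter), gave no such sign, but it exchanged different groups, so the two steps do not establish whether the sugar form alters the response at this position. Nothing at hand accounts for the higher number of compound 4 or says which feature of the exchanged groups matters.

The compounds shown leave open whether the difference lies with the fluorine atoms or with the methoxy group, and a phenyl ring carrying a single fluorine, a 3-chlorophenyl or a 3-aminophenyl at this position would help to separate the two. Within the data shown here, they also leave open what the acetyl groups contribute, as no pair here carries the same aryl group on both the acetylated and the free sugar.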